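The source may hold more compounds than are shown below. What is called first, only, known or untested is meant among the compounds shown, and "the series" means these compounds.

Three compounds share one core and differ only in the group on the urea carbonyl. In a functional assay on HEK293 cells for agonist activity at Vasopressin V2 receptor (Homo sapiens), read by a luciferase reporter and cAMP accumulation (a higher number here means that more compound is needed for the effect, a lower number that less compound is needed), compound 1 `Cc1cc(C(=O)N2CCCCc3ccccc32)ccc1CNC(=O)Nc1ccccc1F` gives 30 nM, compound 2 `Cc1cc(C(=O)N2CCCCc3ccccc32)ccc1CNC(=O)NCC(=O)N(C)C` gives 58 nM, and compound 3 `Cc1cc(C(=O)N2CCCCc3ccccc32)ccc1CNC(=O)N1CCC[C@H]1C(=O)O` gives 680 nM. Compound 3 thus carries the highest number of the three, a gap that is beyond the scatter on both sides: a 23-fold higher number from compound 1 to compound 3 (1.36 log units; beyond the scatter) and a 12-fold higher number from compound 2 to compound 3 (1.07 log units; beyond the scatter), while a 1.9-fold higher number from compound 1 to compound 2 (0.29 log units; within the scatter).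

Compound 4 `CO[C@@H]1C[C@@H](C(=O)N(C)C)N(C(=O)NCc2ccc(C(=O)N3CCCCc4ccccc43)cc2C)C1` starts from compound 3 with one change: 2-(dimethylcarbamoyl)-4-methoxypyrrolidin-1-yl in place of 2-carboxypyrrolidin-1-yl on a carbonyl carbon. The two large steps above both concern the arrival of the 2-carboxypyrrolidin-1-yl group, and the step from compound 3 to compound 4 removes that very group. Compound 2, whose chain also carries a dimethylcarbamoyl group, sits far lower than compound 3 in this assay. A return toward the range of compounds 1 and 2 is therefore expected, with a step of an 8.5-fold lower number from compound 3 to compound 4 (0.93 log units; beyond the scatter). For compound 4 the estimate in this assay is 80 nM, expected to lie between 25 nM and 260 nM.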

Compound 4, half-maximal effective concentration: 4.7 nM
Compound 4: the middle estimate sits 17-fold (1.23 log units) above what was measured; measured number outside the range, below it.
By their numbers in this assay, from the lowest: compound 4; then compounds 1 and 2 (each within the scatter of the next); then compound 3.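

At this place on the carbonyl carbon, the range of numbers is wider than compounds 1 to 3 showed: with 2-(dimethylcarbamoyl)-4-methoxypyrrolidin-1-yl in place of 2-carboxypyrrolidin-1-yl, this assay records a 140-fold lower number from compound 3 to compound 4 (2.16 log units; beyond the scatter) and so the five-membered ring, present in both groups, does not by itself go with a high number. The new group also gives a lower number than the groups of the other two compounds, with a 12-fold lower number from compound 2 to compound 4 (1.09 log units; beyond the scatter) and a 6.4-fold lower number from compound 1 to compound 4 (0.81 log units; beyond the scatter) as the steps. Nothing measured here bears on why this is so.

The change replaces the carboxylic acid with a dimethylcarbamoyl group and adds a methoxy in one step, so the compounds shown do not say which of the two carries the effect. Going by these compounds, how the same pyrrolidine would read without the methoxy, or with a hydroxyl in its place, remains open.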